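A few compounds are considered here, and "the series" means these few. Any claim that something is new, unique, unknown or untested is made for them only; others in the source may bear on it.

Three compounds built on one shared core have been examined in a functional assay on PC-3 cells (Homo sapiens) for cytotoxicity, read by MTT assay, with a stated time of 72 h; on this read-out lower numbers stand for stronger inhibition and higher numbers for weaker inhibition. Compound 1 `O=C(Nc1ccc(Oc2ccnc3[nH]ccc23)cc1)c1nccc(-c2ccc(Cl)cc2)n1` is reported in this assay as "not active" (no number reported). Compound 2 `O=C(Nc1ccc(Oc2ccnc3[nH]ccc23)c(F)c1)c1nccc(-c2ccc([N+](=O)[O-])cc2)n1` gives 12100 nM in this assay, and compound 3 `COc1ccc(-c2ccnc(C(=O)Nc3ccc(Oc4ccnc5[nH]ccc45)c(F)c3)n2)cc1` gives 14100 nM. The step of a 1.2-fold higher number from compound 2 to compound 3 (0.07 log units; within the scatter) is too small to separate the two, so compound 3 stands at one end of the two reported numbers without being distinguished from compound 2.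

Compound 4 `O=C(Nc1ccc(Oc2ccnc3[nH]ccc23)c(F)c1)c1nccc(-c2ccc(Cl)cc2)n1` differs from compound 3 by chloro in place of methoxy on an aromatic carbon. Going by the values given here, only one measured step touches this part of the molecule, the exchange of nitro for methoxy from compound 2 to compound 3, and it moved the number by no more than the scatter. A second observation weighs more heavily: compound 1 carries the same chloro group as compound 4 but lacks the fluorine on the central ring, and in this assay compound 1 gave "not active" (no number reported). Compound 4 is therefore expected to show a step of a 1.4-fold higher number from compound 3 to compound 4 (0.15 log units; within the scatter), with a real chance that the assay returns no number at all because compound 1 gave "not active" (no number reported). The half-maximal inhibitory concentration of compound 4 is estimated at 20000 nM, within a range from 8000 nM to 60000 nM.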

Compound 4, half-maximal inhibitory concentration: 14600 nM
Beside the measured number, compound 4's estimate is 1.4-fold (0.14 log units) above it; measured number inside the range.
By their numbers in this assay, from the lowest: compounds 2, 3 and 4 (each within the scatter of the next).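

In this assay the exchange of 4-methoxyphenyl for 4-chlorophenyl gives a 1.0-fold higher number from compound 3 to compound 4 (0.02 log units; within the scatter) and the exchange of nitro for chloro on the same aromatic carbon gives a 1.2-fold higher number from compound 2 to compound 4 (0.08 log units; within the scatter) so nitro, methoxy and chloro at this place cannot be told apart by their numbers. The chloro group also proves compatible with a measurable number: compound 1, which has chloro but no fluorine, is reported as "not active" (no number reported) while compound 4, which has both, gives 14600 nM and the step between this pair cannot be read, as one of the two has no number. No measurement at hand offers an explanation for either observation.

The compounds shown leave open whether an amine or a carboxylic acid on this aromatic carbon would move the number beyond the scatter. They also leave open how far the fluorine matters with the other groups, for among these compounds only chloro appears without it.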